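Fluoro Substitution on the Phenyl Ring of Compound 2

The source may hold more compounds than are shown below. What is called first, only, known or untested is meant among the compounds shown, and "the series" means these compounds.

Compound 2 `CCc1ccccc1-c1n[nH]c(-c2ccccc2)n1` gives 5 mg/kg in a functional assay on the whole organism (Cricetulus griseus) with Cricetinae gen. sp. as the target; a higher number here means that more compound is needed for the effect, a lower number that less compound is needed. It stands level with compound 3 `CCc1ccccc1-c1n[nH]c(-c2ccc(OC)cc2)n1`, which gives 5 mg/kg; together these two hold the lowest numbers of the three measured. Compound 1 `Cc1ccccc1-c1n[nH]c(-c2ccccc2)n1` gives 10 mg/kg, and the step of a 2.0-fold lower number from compound 1 to compound 2 (0.30 log units; within the scatter) lies within the scatter. Compound 4 `CCc1ccccc1-c1n[nH]c(-c2cccc(F)c2)n1` differs from compound 2 by fluoro in place of hydrogen on an aromatic carbon. Among the compounds with values here, the only measured step that bears on this change is no change at the digits printed from compound 2 to compound 3 (within the scatter), a substituent entering the same six-membered aromatic ring of carbon only, and it stayed within the scatter. No step beyond the scatter is therefore expected here either. Compound 4 is expected to give 5 mg/kg in this assay, with a range from 2.5 mg/kg to 10 mg/kg. The expected step of no change at the digits printed from compound 2 to compound 4 (within the scatter) is estimated to lie within the scatter.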

Compound 4, dose for half-maximal effect: > 5 mg/kg
Compound 4 ended at the assay's limit (the forecaster's own chance of this, stated with the estimate: 5%); the middle value lies on the limit itself.
By their numbers in this assay, from the lowest: compounds 2, 3 and 1 (each within the scatter of the next).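

In this assay compound 4 gives > 5 mg/kg and this is a limit of the assay, not a number. Within the data shown here, the step is a number no lower from compound 2 to compound 4 (the limit leaves the size open) and so shows that fluoro on this aromatic carbon, meta to a large group, brought no lower number, which the earlier compounds could not show for this place. The reading of this compound stops at the edge of the assay: the limit of > 5 mg/kg in this assay, at which 1 of the 4 values shown sits. From the compounds shown here alone, how large the step to compound 4 really is stays open. So does what chloro, an amine or a carboxylic acid would do at this same carbon.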